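Replacing Trifluoromethyl by Amino in Compound 3

This account rests on a few compounds, and the source may have more. Where it says the series, first, only, none or still open, it means among the compounds named here.

For the measured compounds named here, compound 3 `O=C(O)CCc1ccc(C#Cc2cccc(C(F)(F)F)c2)cc1` gives 89.1 nM in an in vitro functional assay on 1321-N1 cells for agonist activity at Free fatty acid receptor 1 (Homo sapiens), read by fluorescence (on this read-out lower numbers stand for an effect already at smaller amounts and higher numbers for an effect only at larger amounts of compound), the lowest of the three numbers known here: compound 1 `O=Cc1cccc(C#Cc2ccc(CCC(=O)O)cc2)c1` gives 355 nM and compound 2 `O=C(O)CCc1ccc(C#Cc2cccc(CO)c2)cc1` gives 891 nM. Compound 4 `Nc1cccc(C#Cc2ccc(CCC(=O)O)cc2)c1` differs from compound 3 by amino in place of trifluoromethyl on an aromatic carbon; the entering group brings 1 hydrogen-bond donor and 1 hydrogen-bond acceptor. Going by the values given here, two measured steps bear on this change: a 4.0-fold lower number from compound 1 to compound 3 (0.60 log units; beyond the scatter) and a 10-fold lower number from compound 2 to compound 3 (1.00 log units; beyond the scatter), so the trifluoromethyl of compound 3 outperformed both formyl and hydroxymethyl on the same aromatic carbon. Going back from trifluoromethyl to a small single-atom group, compound 4 is therefore expected to give a higher number than compound 3, estimated as a 5.6-fold higher number from compound 3 to compound 4 (0.75 log units; beyond the scatter). The estimate for compound 4 is 500 nM, within 150 nM to 2000 nM.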

Compound 4, half-maximal effective concentration: 1100 nM
For compound 4 the middle estimate is 2.2-fold (0.34 log units) below the measured one; the range from low to high includes it.
By their numbers in this assay, from the lowest: compound 3; then compound 1; then compounds 2 and 4 (each within the scatter of the next).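

Amino costs much at this aromatic carbon (a 12-fold higher number from compound 3 to compound 4 (1.09 log units; beyond the scatter)), and the loss is not confined to the comparison with trifluoromethyl: formyl also gives a lower number (a 3.1-fold higher number from compound 1 to compound 4 (0.49 log units; beyond the scatter)), whereas hydroxymethyl and amino stay within the scatter of each other (a 1.2-fold higher number from compound 2 to compound 4 (0.09 log units; within the scatter)). Among the four groups on this carbon, amino and hydroxymethyl thus share the high end, with formyl and then trifluoromethyl lower. No measurement shown accounts for this ordering. From the compounds shown here alone, whether methyl, chloro or nitrile here would come close to trifluoromethyl remains open, as does whether an acetamide or dimethylamino group would differ from amino.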